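Cyclohexyl to dichlorophenyl ether in an iminosugar series

The source may report more compounds than this note shows. Statements on the series, on what has been measured and on what is new or still open speak of the compounds shown alone.

Compound 1 `CC1CCCC(OCCCCCCN2C[C@H](O)[C@@H](O)[C@H](O)[C@H]2CO)C1C` and compound 2 `Cc1ccc(C(C)C)cc1OCCCCCCN1C[C@H](O)[C@@H](O)[C@H](O)[C@H]1CO` share the same core and a six-carbon chain ending in an ether. In an ADME assay on MDBK cells (Bos taurus) for cytotoxicity, read by MTT assay (a lower number here means that less compound is tolerated, a higher number that more compound is tolerated), compound 1 reaches only a limit of the assay, > 500000 nM, so no number is known for it (the limit of > 500000 nM in this assay, at which 1 of the 2 values shown sits). In this assay compound 2 gives 90000 nM. For the measured compounds named here, of this pair the values show only that compound 2 sits at a measured number while compound 1 sits at the limit.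

Compound 3 `OC[C@@H]1[C@@H](O)[C@H](O)[C@@H](O)CN1CCCCCCOc1cc(Cl)ccc1Cl` differs from compound 1 by a group of 8 heavy atoms (6 carbon, 2 chlorine; one six-membered aromatic ring of carbon only) in place of a group of 8 heavy atoms (8 carbon; one six-membered non-aromatic ring of carbon only), on an oxygen on a saturated carbon. Going by the values given here, no measured pair covers this change, so any expectation rests on compound 2, which also carries an aromatic ether and gives 90000 nM in this assay. The expected step is an at least 5.0-fold lower number from compound 1 to compound 3 (0.69 log units; beyond the scatter), downward from the limit and well beyond the scatter. Compound 3 is estimated at 100000 nM, with a range of 30000 nM to 400000 nM.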

Compound 3, half-maximal cytotoxic concentration: 320000 nM
Compound 3: the middle estimate sits 3.2-fold (0.51 log units) below what was measured; the range from low to high includes it.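

The change at the oxygen on a saturated carbon, from the saturated carbon ring to 2,5-dichlorophenyl, now has its first direct reading in this assay: the step is an at least 1.5-fold lower number from compound 1 to compound 3 (0.19 log units; that floor lies within the scatter). Compound 1 stands at a limit of the assay, > 500000 nM, and that limit is not a number. The step is therefore only a floor, so the data do not settle whether the true change lies within the scatter or well beyond it, because one end of the pair rests on a limit: the limit of > 500000 nM in this assay, at which 1 of the 3 values shown sits.

An unsubstituted phenyl ether would separate the part played by the aromatic ring from that of the two chlorine atoms. From the compounds shown here alone, how an amine on the ring or a longer chain would read in this assay also remains open.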